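The source may report more compounds than this note shows. Statements on the series, on what has been measured and on what is new or still open speak of the compounds shown alone.

Compound 3, `O=C(c1ccc(F)cc1)N1CCc2nc(COc3ccccn3)oc2C1`, stands second highest of the three numbers recorded in a functional assay on HEK293 cells for positive allosteric modulation of metabotropic glutamate receptor 5 (Homo sapiens), read by calcium flux; on this read-out lower numbers stand for smaller maximal responses and higher numbers for larger maximal responses: compound 3 gives 75%. Its nearest neighbour is compound 1, `O=C(c1ccc(F)cc1)N1CCc2nc(COc3ccccc3F)oc2C1`, which in this assay gives 78%, the two lying within the scatter of each other, as a number 3 percentage points lower from compound 1 to compound 3 (within the scatter) shows. The furthest is compound 2, `O=C(c1ccc(F)cc1)N1CCc2nc(COc3ccc(F)c(F)c3)oc2C1`, which in this assay gives 40%; the gap a number 35 percentage points higher from compound 2 to compound 3 (beyond the scatter) is large, as is a number 38 percentage points lower from compound 1 to compound 2 (beyond the scatter).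

Compound 4, `O=C(c1ccc(F)cc1)N1CCc2nc(COc3cccnc3)oc2C1`, differs from compound 3 by pyridin-3-yl in place of pyridin-2-yl on an oxygen on a saturated carbon. For the measured compounds named here, no measured step swaps one pyridinyl for another, so there is no direct precedent. The steps that do bear on it concern the same oxygen on a saturated carbon: one replacement there left the response unchanged within the scatter, two others moved it by a large amount. The change is therefore expected to be modest, with the possibility of a drop not excluded.

For compound 4 the estimate in this assay is 65%, within a range from 40% to 85%; the expected step is a number 10 percentage points lower from compound 3 to compound 4 (within the scatter).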

Compound 4, largest response reached (reported as percent of maximum), in percent of the reference or control that the assay uses: 40%
For compound 4 the middle estimate is 25 percentage points above the measured one, and the stated range covers the measured number.
By their numbers in this assay, from the lowest: compounds 2 and 4 (each within the scatter of the next); then compounds 3 and 1 (each within the scatter of the next).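

In this assay, the exchange of pyridin-2-yl for pyridin-3-yl keeps the same atoms and the same counts, yet it gives a number 35 percentage points lower from compound 3 to compound 4 (beyond the scatter), so at this position the response depends on how the ring is joined and not only on what it contains. With a number 38 percentage points lower from compound 1 to compound 4 (beyond the scatter) and no change at the digits printed from compound 2 to compound 4 (within the scatter), the four compounds fall into two levels, compounds 1 and 3 at one and compounds 2 and 4 at the other, and each level holds one fluorinated phenyl and one pyridinyl, so neither ring type alone sets the level. Nothing in the data at hand accounts for this split.

Going by these compounds, whether pyridin-4-yl on the same oxygen would join compound 3 or compound 4 remains open. So does the level of 3-fluorophenyl or 4-fluorophenyl there, and how far either level holds for other groups.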